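The source may hold more compounds than are shown below. What is called first, only, known or untested is meant among the compounds shown, and "the series" means these compounds.

Measured so far in a functional assay on OVCAR-8 cells (Homo sapiens); on this read-out lower numbers stand for stronger inhibition of growth and higher numbers for weaker inhibition of growth:
- compound 1 `O=S(=O)(/C=C/c1ccc(Cl)c(Cl)c1)Cc1ccc(Nc2ncnc3ccccc23)cc1`: 14000 nM
- compound 2 `O=S(=O)(/C=C/c1ccc(F)cc1F)Cc1ccc(Nc2ncnc3ccccc23)cc1`: > 100000 nM, a limit of the assay and not a number

Compound 2 has no number on this read-out, only (the limit of > 100000 nM in this assay, at which 1 of the 2 values shown sits). Compound 3 `O=S(=O)(/C=C/c1ccc(F)cc1Cl)Cc1ccc(Nc2ncnc3ccccc23)cc1` differs from it at one site: chloro in place of fluoro on an aromatic carbon. This is chloro in place of fluoro on an aromatic carbon, ortho to a large group and meta to a fluoro group.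

Within the data shown here, one measured step bears on this: an at least 7.1-fold higher number from compound 1 to compound 2 (0.85 log units; beyond the scatter), beyond the scatter, with 2,4-difluorophenyl in place of 3,4-dichlorophenyl. That step replaces both halogens and alters the substitution pattern, so it does not isolate the present replacement. In this single pair, compound 1 carries chloro groups and gives 14000 nM. A move toward a lower number in this assay is therefore expected for compound 3, probably smaller than the measured step, and another limit result remains possible.

The estimated step is an at least 2.5-fold lower number from compound 2 to compound 3 (0.39 log units; beyond the scatter). For compound 3 the expected value is 40000 nM, with an estimated range of 12000 nM to 100000 nM.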

Compound 3, concentration for 50% growth inhibition: 100000 nM
Compound 3: middle estimate off by 2.5-fold (0.40 log units), on the low side; the range from low to high includes it.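

In this assay compound 3 gives 100000 nM, a measured number. Compound 2 holds only a limit of the assay, so the size of the step between the two cannot be read: the limit of > 100000 nM in this assay, at which 1 of the 3 values shown sits.

The chloro in place of fluoro, on the aromatic carbon ortho to a large group and meta to a fluoro group, therefore brings a number no higher from compound 2 to compound 3 (the limit leaves the size open), and no gain of any definite size can be claimed for it. The comparison that can be read is a 7.1-fold higher number from compound 1 to compound 3 (0.85 log units; beyond the scatter), with 2-chloro-4-fluorophenyl in place of 3,4-dichlorophenyl, so a chloro group at this position, kept together with the fluoro group, does not match the growth inhibition seen with the 3,4-dichlorophenyl group of compound 1.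

The compounds shown leave open which of the two chloro groups of compound 1 accounts for that difference, since compound 3 changes both sites at once. They also leave open whether a methoxy group or an amine at the position of this chloro group would move the number in this assay in either direction.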